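The source may hold more compounds than are shown below. What is called first, only, known or untested is meant among the compounds shown, and "the series" means these compounds.

Measured compounds:
compound 1, `O=C(Nc1ccc(Oc2ccnc3[nH]ccc23)c(F)c1)c1cc2cccnc2n(-c2ccc(F)c(Cl)c2)c1=O`: 630 nM
compound 2, `Cn1ccc2c(Oc3ccc(NC(=O)c4cc5cccnc5n(-c5ccc(Cl)cc5)c4=O)cc3F)ccnc21`: 350 nM

Both compounds were tested in a functional assay on A549 cells (Homo sapiens) for antiproliferative activity, read by MTT assay, with a stated time of 72 h; on this read-out higher numbers stand for weaker inhibition and lower numbers for stronger inhibition. In this assay compound 1 gives 630 nM, and compound 2 gives 350 nM. Compound 2 has the lower of the two numbers, but the gap to compound 1 lies within the usual scatter of repeated measurements, so the two cannot be told apart on this evidence.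

Compound 3, `Cn1ccc2c(Oc3ccc(NC(=O)c4cc5cccnc5n(-c5ccc(F)c(Cl)c5)c4=O)cc3F)ccnc21`, has not yet been measured in this assay. It differs from compound 2 in one place: 3-chloro-4-fluorophenyl in place of 4-chlorophenyl on an aromatic nitrogen. Among the measured compounds shown here, the same 3-chloro-4-fluorophenyl group is already present in compound 1, which however differs from compound 2 in a second place as well, so no pair of measured compounds isolates this single change. Since the two measured numbers are themselves within the scatter of each other, the expected step of a 1.1-fold higher number from compound 2 to compound 3 (0.06 log units; within the scatter) is small and not beyond the scatter in either direction. Compound 3 is expected to give about 400 nM, with a range from 150 nM to 1100 nM.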

Compound 3, half-maximal inhibitory concentration: 3560 nM
Compound 3: middle estimate off by 8.9-fold (0.95 log units), on the low side; the whole stated range lies below it.
By their numbers in this assay, from the lowest: compounds 2 and 1 (each within the scatter of the next); then compound 3.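

In this assay, the group on the aromatic nitrogen of the shared core proves far from interchangeable: 3-chloro-4-fluorophenyl in place of 4-chlorophenyl gives a 10-fold higher number from compound 2 to compound 3 (1.01 log units; beyond the scatter), so a small change to the substituents on this phenyl ring can weaken inhibition markedly. A second comparison, at a different place, shows that with 3-chloro-4-fluorophenyl held constant, methyl in place of hydrogen on an aromatic nitrogen gives a 5.7-fold higher number from compound 1 to compound 3 (0.75 log units; beyond the scatter), so this small addition is also not neutral in this setting. No measurement is available that explains either step.

The compounds shown leave open whether the loss comes from the added fluorine or from the changed place of the chlorine, and whether the step from 4-chlorophenyl to 3-chloro-4-fluorophenyl would be as large with hydrogen instead of methyl on the other nitrogen. They also leave open how an unsubstituted phenyl, or a phenyl carrying a methoxy group, would behave on this nitrogen.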